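A few compounds are considered here, and "the series" means these few. Any claim that something is new, unique, unknown or untested is made for them only; others in the source may bear on it.

The measured compounds are compound 1 `Cc1ccc(-n2nc(C(=O)Nc3ccc(Oc4ncnc5[nH]ccc45)cc3)c(C)cc2=O)cc1`, compound 2 `Cc1cc(=O)n(-c2ccc(Br)cc2F)nc1C(=O)Nc1ccc(Oc2ncnc3[nH]ccc23)cc1` and compound 3 `Cc1cc(=O)n(-c2cccc(C(F)(F)F)c2)nc1C(=O)Nc1ccc(Oc2ncnc3[nH]ccc23)cc1`. In a functional assay on HepG2 cells (Homo sapiens) for cytotoxicity, read by MTT assay, with a stated time of 72 h (on this read-out lower numbers stand for stronger inhibition and higher numbers for weaker inhibition), compound 1 gives 7460 nM, compound 2 gives 3660 nM, and compound 3 gives 9470 nM. Compound 1 stands second highest of the three: compound 3 is nearest (a 1.3-fold higher number from compound 1 to compound 3 (0.10 log units; within the scatter)) and compound 2 furthest (a 2.0-fold lower number from compound 1 to compound 2 (0.31 log units; beyond the scatter)).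

Compound 4 `Cc1ccc(-n2nc(C(=O)Nc3ccc(Oc4ncnc5[nH]ccc45)c(F)c3)c(C)cc2=O)cc1` differs from compound 1 by fluoro in place of hydrogen on an aromatic carbon. Every measured step varies the aryl group on the aromatic nitrogen instead, so none bears directly on this change; the steps of a 2.0-fold lower number from compound 1 to compound 2 (0.31 log units; beyond the scatter) and a 2.6-fold higher number from compound 2 to compound 3 (0.41 log units; beyond the scatter) only show that the set spans a modest range. Going by the values given here, with no direct precedent, a step in this assay no larger than the scatter is expected, a 1.1-fold lower number from compound 1 to compound 4 (0.03 log units; within the scatter). Compound 4 is therefore estimated at 7000 nM, with a range from 3500 nM to 14000 nM.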

Compound 4, half-maximal inhibitory concentration: 18800 nM
Beside the measured number, compound 4's estimate is 2.7-fold (0.43 log units) below it; measured number above the stated range.
By their numbers in this assay, from the lowest: compound 2; then compounds 1, 3 and 4 (each within the scatter of the next, the first and the last beyond it).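

The aromatic carbon ortho to a large group and meta to a large group proves responsive: in this assay, a single fluoro in place of hydrogen gives a 2.5-fold higher number from compound 1 to compound 4 (0.40 log units; beyond the scatter), which means weaker inhibition. The earlier compounds shown here varied only the aryl group on the aromatic nitrogen, and this one atom moves the number about as far as a 2.6-fold higher number from compound 2 to compound 3 (0.41 log units; beyond the scatter) did there. Nothing measured here accounts for this shift. As far as these compounds go, whether chloro, methoxy or an amine on this carbon would act likewise stays open, as does whether fluoro there has the same effect with 4-bromo-2-fluorophenyl on the aromatic nitrogen.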